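This account rests on a few compounds, and the source may have more. Where it says the series, first, only, none or still open, it means among the compounds named here.

Measured compounds:
Compound 1 `COc1ccc(NC(=O)CSc2nc3ccc(N4CCN(C)CC4)nc3[nH]2)cc1OC`: in an assay on isolated protein for inhibition of Ectonucleotide pyrophosphatase/phosphodiesterase family member 1 (Homo sapiens), tested at 10 uM (a lower number here means less inhibition, a higher number more inhibition at the concentration tested (going by the name of the read-out)), compound 1 gives 35%
Compound 2 `O=C(CSc1nc2cccnc2[nH]1)Nc1ccccc1Cl`: in this assay compound 2 gives 19%
Compound 3 `Cc1ccc(NC(=O)CSc2nc3cccnc3[nH]2)cc1C`: in this assay compound 3 gives 11%

Among these three, compound 1 stands highest. Compound 2 is the nearest to it, with a number that lies beyond the usual scatter below it, and compound 3 lies further down still, also beyond the scatter. The shared core carries an amide linked to a substituted aromatic ring in each case, and compound 1 is the only one of the three that carries an extra group on the fused ring of its core.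

Compound 4 `COc1ccc(NC(=O)CSc2nc3ccc(OCC(F)(F)F)nc3[nH]2)cc1OC` has not yet been tested. It is derived from compound 1 by one change: 2,2,2-trifluoroethoxy in place of 4-methylpiperazin-1-yl on an aromatic carbon. For the measured compounds named here, no measured pair shows what this kind of swap does in this assay, so the direction and size of the step cannot be read from the numbers at hand. Because compound 1 sits at 35% and the other two compounds sit lower, a modest downward step is the more cautious expectation, though a value close to compound 1 is also plausible. The expected step from compound 1 to compound 4 is estimated at a number 10 percentage points lower from compound 1 to compound 4 (within the scatter). Compound 4 is therefore expected to give about 25%, with a likely range from 5% to 45%.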

Compound 4, a percentage reported as inhibition, at one concentration (the size of the read-out at that concentration, not a potency): 61%
The estimate for compound 4 lay 36 percentage points below the measured number; the whole stated range lies below it.
By their numbers in this assay, from the lowest: compounds 3 and 2 (each within the scatter of the next); then compound 1; then compound 4.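

Replacing 4-methylpiperazin-1-yl with 2,2,2-trifluoroethoxy on an aromatic carbon of the shared core gives a number 26 percentage points higher from compound 1 to compound 4 (beyond the scatter) in this assay. For the compounds shown here, the earlier compounds differ from one another in more than one place, so this is the first pair to isolate this position, and it shows that the group on this carbon, next to the ring nitrogen, can change the inhibition read-out by more than the usual scatter. Nothing available explains why this swap raises the number.

A single swap cannot show whether the step follows the oxygen link, the fluorine atoms or the loss of the ring. A plain ethoxy group or a morpholine ring on the same carbon would help separate these possibilities.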